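The compounds below may be only part of what the source reports. "The series", "measured", "known", "first", "only" and "open" are said of these compounds alone.

Measured compounds in a functional assay on HepG2 cells (Homo sapiens) for cytotoxicity, read by MTT assay, with a stated time of 48 h; a higher number here means a weaker inhibitor, a lower number a stronger inhibitor:
Compound 1 `CCc1nnc(SCc2ccccc2)n1N1C(=O)c2ccccc2C1=O` gives > 200000 nM, which is a limit of the assay and not a number.
Compound 2 `COc1cc(-c2nnc(SCC(=O)c3ccc(Cl)cc3)n2N2C(=O)c3ccccc3C2=O)cc(OC)c1OC` gives 22000 nM.
Compound 3 `COc1cc(-c2nnc(SCC(=O)c3ccc(C)cc3)n2N2C(=O)c3ccccc3C2=O)cc(OC)c1OC` gives 9440 nM.

Among the compounds with values here, compound 3 stands at the lowest of the two numbers in this assay; the nearest is compound 2, and the single measured step, a 2.3-fold lower number from compound 2 to compound 3 (0.37 log units; beyond the scatter), is a methyl in place of chloro on an aromatic carbon. Compound 1, the only other entry, sits at the limit of > 200000 nM in this assay, at which 1 of the 3 values shown sits.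

Compound 4 `COc1cc(-c2nnc(SCc3ccccc3)n2N2C(=O)c3ccccc3C2=O)cc(OC)c1OC` has not yet been measured. It differs from compound 3 by phenyl in place of (4-methylphenyl)carbonyl on a saturated chain carbon bound to a sulfur. The measured step of a 2.3-fold lower number from compound 2 to compound 3 (0.37 log units; beyond the scatter) alters a substituent on the aromatic ring that leaves entirely here, so it gives no direct guide to this change. What the shown data offer instead is compound 1, which carries the same benzylsulfanyl chain as compound 4 but a different group on the shared core, and compound 1 shows only a limit. The expected step of a 5.3-fold higher number from compound 3 to compound 4 (0.72 log units; beyond the scatter) is therefore toward a higher number, with wide uncertainty and a real chance that only a limit is recorded.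

Compound 4 is estimated to give 50000 nM, expected to lie between 10000 nM and 250000 nM.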

Compound 4, half-maximal inhibitory concentration: > 200000 nM
Compound 4: no number, only a limit; the forecaster's own chance of this, stated with the estimate: 40%; middle value at least 4.0-fold (0.60 log units) away from the limit.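

In this assay, the chain on the sulfur now emerges as the more sensitive place in the series: phenyl in place of (4-methylphenyl)carbonyl on a saturated chain carbon bound to a sulfur gives an at least 21-fold higher number from compound 3 to compound 4 (1.32 log units; beyond the scatter), and the earlier change on the aromatic ring gave only a 2.3-fold lower number from compound 2 to compound 3 (0.37 log units; beyond the scatter). The same change from the chloro member, phenyl in place of (4-chlorophenyl)carbonyl, gives an at least 9.0-fold higher number from compound 2 to compound 4 (0.95 log units; beyond the scatter), so the loss appears with both ring substituents, and among the compounds shown only those with a carbonyl in this chain give a number. Compound 1 and compound 4, both with the benzylsulfanyl chain, give limits and not numbers, and the step between them cannot be read, so the effect of 3,4,5-trimethoxyphenyl in place of ethyl stays without a size: the limit of > 200000 nM in this assay, at which 2 of the 4 values shown sit.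

These steps remove the carbonyl and the ring substituent together, and the compounds shown do not separate the two. A plain phenylcarbonyl chain, a phenethyl chain or an amide in place of the ketone at this position would be needed to tell which part of the chain the number follows.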